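The source may hold more compounds than are shown below. What is called first, only, known or untested is meant among the compounds shown, and "the series" means these compounds.

Going by the values given here, compound 2 `CCN1CCN(c2cn(S(=O)(=O)c3ccc(F)cc3)c3ccc(Br)cc23)CC1` holds the lowest of the two numbers known in an assay on HeLa cells for displacement of a labelled ligand from 5-hydroxytryptamine receptor 6 (Homo sapiens); a higher number here means a weaker inhibitor, a lower number a stronger inhibitor; there compound 2 gives 10.6 nM. Among the compounds with values here, its only neighbour, compound 1 `CCN1CCN(c2cn(S(=O)(=O)c3ccc(C(C)C)cc3)c3ccc(Cl)cc23)CC1`, gives 30.5 nM in this assay, a gap beyond the scatter. Compound 3 `CCN1CCN(c2cn(S(=O)(=O)c3ccc(C(C)C)cc3)c3ccc(Br)cc23)CC1` is compound 2 with isopropyl in place of fluoro on an aromatic carbon. Within the data shown here, no measured pair carries this change alone; compound 1 shares the isopropyl yet also a different halogen, so the direction rests on that single comparison. A modest move towards a higher number is expected, a 1.9-fold higher number from compound 2 to compound 3 (0.28 log units; within the scatter). Compound 3 is estimated at 20 nM, within 7 nM to 60 nM.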

Compound 3, inhibition constant: 30.1 nM
Estimate against measurement, compound 3: 1.5-fold (0.18 log units) below; the range from low to high includes it.
By their numbers in this assay, from the lowest: compound 2; then compounds 3 and 1 (each within the scatter of the next).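

In this assay the change of fluoro to isopropyl, on an aromatic carbon para to a large group, now stands alone and gives a 2.8-fold higher number from compound 2 to compound 3 (0.45 log units; beyond the scatter) as a step beyond the scatter. With isopropyl held, bromo in place of chloro gives a 1.0-fold lower number from compound 1 to compound 3 (0.01 log units; within the scatter) within the scatter, so this pair shows no readable effect of that halogen change. Nothing at hand explains the isopropyl step. On these data alone, whether an amine or a carboxylic acid at this place would sit nearer compound 2 or compound 3 remains open. Also open, as far as these compounds go, is whether the fluoro to isopropyl step holds with chloro on the core.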